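The compounds below may be only part of what the source reports. "The series", "measured", "known", "first", "only" and "open" are said of these compounds alone.

Compound 1 `N=c1oc2c(O)cccc2cc1C(=O)Nc1cccc(F)c1`: 370 nM
Compound 2 `Cc1ccc(NC(=O)c2cc3cccc(O)c3oc2=N)cc1`: 270 nM

Both compounds were tested in an assay on isolated protein for inhibition of Carbonyl reductase [NADPH] 1 (Homo sapiens); a lower number here means a stronger inhibitor, a higher number a weaker inhibitor. Compound 1 gives 370 nM there, and compound 2 gives 270 nM; the one measured step, a 1.4-fold lower number from compound 1 to compound 2 (0.14 log units; within the scatter), lies within the scatter, so compound 1 stands level with the only other number shown.

Compound 3 `CCc1cccc(NC(=O)c2cc3cccc(O)c3oc2=N)c1` has not been measured. It differs from compound 1 by ethyl in place of fluoro on an aromatic carbon. Among the measured compounds shown here, the only step that bears on this change is the one from compound 1 to compound 2, which also swaps the group on the ring attached to the amide-type nitrogen and stays within the scatter. On that basis no step beyond the scatter is expected in this assay for compound 3 either, although a single within-scatter step is a thin footing. Compound 3 is therefore estimated at 320 nM, in a range of 120 nM to 850 nM, which amounts to an expected step of a 1.2-fold lower number from compound 1 to compound 3 (0.06 log units; within the scatter).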

Compound 3, half-maximal inhibitory concentration: 250 nM
For compound 3 the middle estimate is 1.3-fold (0.11 log units) above the measured one, within the range that was stated.
By their numbers in this assay, from the lowest: compounds 3, 2 and 1 (each within the scatter of the next).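

In this assay, putting ethyl in place of fluoro on an aromatic carbon, meta to a large group, gives a 1.5-fold lower number from compound 1 to compound 3 (0.17 log units; within the scatter) and so leaves the number level. Unlike the step to compound 2, which moves the substituent on the ring as well as changing it, this change swaps the group at one position only. It shows that ethyl, with 2 heavy atoms, can stand where the single fluorine stood without a step beyond the scatter. No measurement shown offers a reason for this result.

Going by these compounds, whether the same position also accepts an amine or a carboxylic acid remains open. So does the outcome with a longer chain such as butyl, or with a ring such as phenyl.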